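The source may report more compounds than this note shows. Statements on the series, on what has been measured and on what is new or still open speak of the compounds shown alone.

Measured in a functional assay on SiHa cells (Homo sapiens) for inhibition, read by CCK-8 assay, with a stated time of 72 h, tested at 1 uM; a higher number here means more inhibition of growth at the concentration tested, a lower number less inhibition of growth:
Compound 1 `CN(C)C(=O)c1cc2cnc(Nc3ccc(NC(=O)C4(C(=O)Nc5ccc(Cl)cc5)CC4)cc3)nc2n1C1CCCC1`: -0.8%
Compound 2 `CN(C)C(=O)c1cc2cnc(Nc3ccc(NC(=O)C4(C(=O)Nc5cccc(F)c5)CC4)cc3)nc2n1C1CCCC1`: 29.7%
Compound 3 `Cc1ccc(NC(=O)C2(C(=O)Nc3ccc(Nc4ncc5cc(C(=O)N(C)C)n(C6CCCC6)c5n4)cc3)CC2)cc1`: 37%

Compound 3 cannot be separated from its nearest neighbour, a number 7.3 percentage points higher from compound 2 to compound 3 (within the scatter), but it stands clear of the furthest, a number 37.8 percentage points higher from compound 1 to compound 3 (beyond the scatter). Compound 4 `CN(C)C(=O)c1cc2cnc(Nc3ccc(NC(=O)C4(C(=O)Nc5ccc(O)cc5)CC4)cc3)nc2n1C1CCCC1` carries hydroxy in place of methyl on an aromatic carbon, para to a large group: hydroxy in place of methyl on an aromatic carbon. It is thus the 4-hydroxyphenyl counterpart of the 4-methylphenyl compound 3.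

The step bearing most directly on this change is the exchange of chloro and methyl at the same place, a number 37.8 percentage points higher from compound 1 to compound 3 (beyond the scatter), which is large. The change from the 4-chlorophenyl to the 3-fluorophenyl group, a number 30.5 percentage points higher from compound 1 to compound 2 (beyond the scatter), is also large. Together they show that this ring can move the read-out considerably, yet no measured compound carries hydroxy, so the data do not fix the direction. A moderate fall is expected in this assay, a number 15 percentage points lower from compound 3 to compound 4 (beyond the scatter), though with wide uncertainty. Compound 4 is estimated at 22%, with an expected range from 0% to 42%.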

Compound 4, percent growth inhibition at one concentration: 69.5%
The estimate for compound 4 lay 47.5 percentage points below the measured number; the whole stated range lies below it.
By their numbers in this assay, from the lowest: compound 1; then compounds 2 and 3 (each within the scatter of the next); then compound 4.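

In this assay, this place, para to a large group, turns out to tolerate more than the methyl and chloro compounds suggested: hydroxy in place of methyl raises growth inhibition clearly (a number 32.5 percentage points higher from compound 3 to compound 4 (beyond the scatter)), and hydroxy in place of chloro does so by more (a number 70.3 percentage points higher from compound 1 to compound 4 (beyond the scatter)). The 4-hydroxyphenyl group also stands clear of the 3-fluorophenyl group (a number 39.8 percentage points higher from compound 2 to compound 4 (beyond the scatter)), so compound 4 is separated from all three earlier compounds by a change of one heavy atom that adds a hydrogen-bond donor and acceptor. Nothing available explains the size of these steps.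

The compounds shown leave open whether an amino, methoxy or carboxylic acid group at this place would match hydroxy. They also leave open whether the gain for compound 4 holds across a range of concentrations.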